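This account rests on a few compounds, and the source may have more. Where it says the series, first, only, none or still open, it means among the compounds named here.

In a physicochemical assay for solubility, at pH 7.4 (on this read-out lower numbers stand for lower solubility and higher numbers for higher solubility), compound 1 `O=C(O)c1cccc(S(=O)(=O)N2CCC(NS(=O)(=O)c3cc(S(=O)(=O)c4ccccc4)ccc3C(F)(F)F)CC2)c1` reads > 100000 nM, which is a limit and not a number. For the measured compounds named here, compound 2 `O=C([C@H]1CCNC1)N1CCC(NS(=O)(=O)c2cc(S(=O)(=O)c3ccccc3)ccc2C(F)(F)F)CC1` gives 77000 nM, the only actual number available. Compound 3 `O=C([C@@H]1CCNC1)N1CCC(NS(=O)(=O)c2cc(S(=O)(=O)c3ccccc3)ccc2C(F)(F)F)CC1` differs from compound 2 as follows: the two compounds have the same atoms and bonds and differ only in configuration as drawn: 1 of 1 stereo elements differ; a stereocentre at a saturated ring carbon is drawn S in compound 2 and R in compound 3. Going by the values given here, the sole measured step, an at least 1.2-fold lower number from compound 1 to compound 2 (0.11 log units; that floor lies within the scatter), swaps (3-carboxyphenyl)sulfonyl for (pyrrolidin-3-yl)carbonyl, and no measured step tests a change of configuration. With only the value of compound 2 to go on, no step beyond the scatter is expected in this assay. For compound 3 the estimated value is 75000 nM, with an expected range of 38000 nM to 100000 nM. The expected change is a 1.0-fold lower number from compound 2 to compound 3 (0.01 log units; within the scatter).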

Compound 3, solubility: 70000 nM
The estimate for compound 3 lay 1.1-fold (0.03 log units) above the measured number, and the stated range covers the measured number.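

In this assay, the change of configuration at the saturated ring carbon gives a 1.1-fold lower number from compound 2 to compound 3 (0.04 log units; within the scatter), so this read-out does not tell the two drawn forms apart: the fact that compounds 2 and 3 differ only in the configuration as drawn With (pyrrolidin-3-yl)carbonyl in place of (3-carboxyphenyl)sulfonyl, the R form gives an at least 1.4-fold lower number from compound 1 to compound 3 (0.15 log units; that floor lies within the scatter), and this floor matches the S form in also lying within the scatter. The true size of that step remains unknown: the limit of > 100000 nM in this assay, at which 1 of the 3 values shown sits.

From the compounds shown here alone, whether configuration counts for as little when an open-chain amine or a piperidine-3-carbonyl group takes the place of (pyrrolidin-3-yl)carbonyl remains open.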